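Trifluoromethyl gives way to nitro in compound 3

The source may hold more compounds than are shown below. What is called first, only, known or untested is meant among the compounds shown, and "the series" means these compounds.

Compound 1 `Cc1cc(=O)n2nc(SCc3cccc(C(F)(F)F)c3)nc2[nH]1` gives 65800 nM
Compound 2 `Cc1ccc(CSc2nc3[nH]c(C)cc(=O)n3n2)cc1` gives 49900 nM

In a functional assay on NCI-H460 cells (Homo sapiens) for antiproliferative activity, read by MTT assay, with a stated time of 24 h (a higher number here means a weaker inhibitor, a lower number a stronger inhibitor), compound 1 stands at 65800 nM and compound 2 at 49900 nM within the scatter of each other, so compound 1 does not stand apart on these numbers. Compound 3 `Cc1cc(=O)n2nc(SCc3cccc([N+](=O)[O-])c3)nc2[nH]1` keeps the core of compound 1 and changes one group. The change is nitro in place of trifluoromethyl on an aromatic carbon (nitro in place of trifluoromethyl on an aromatic carbon, meta to a large group). Among the compounds with values here, no measured pair shows this change, so the expectation rests on little. Compound 2 carries no trifluoromethyl, yet at 49900 nM it stays within the scatter of compound 1, so no step beyond the scatter is expected in this assay and no direction is favoured. The estimated step is a 1.2-fold lower number from compound 1 to compound 3 (0.08 log units; within the scatter) and is expected to stay within the scatter. For compound 3 the estimated value is 55000 nM with an expected range from 22000 nM to 130000 nM in this measurement.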

Compound 3, half-maximal inhibitory concentration: > 80000 nM
Compound 3 gave a limit, no number; the forecaster's own chance of this, stated with the estimate: 10%; middle value at least 1.4-fold (0.16 log units) away from the limit.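

The reading for compound 3 in this assay is a limit and not a number: the limit of > 80000 nM in this assay, at which 1 of the 3 values shown sits. Within the data shown here, with nitro in place of trifluoromethyl on an aromatic carbon, meta to a large group, the change gives an at least 1.2-fold higher number from compound 1 to compound 3 (0.08 log units; that floor lies within the scatter), the first step between measured compounds that differ in one place. Going by these compounds, the result shows that this replacement brings no gain in this assay, although its floor alone does not establish a loss, and the true size of the step stays unknown.

On these data alone, how far compound 3 lies past its limit remains open, and so does the direction of the step beyond its floor. Also open, as far as these compounds go, is whether an amine or a carboxylic acid on this aromatic carbon would give a number that stands apart from compound 1.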